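From Nitro to Tert-Butyl: Expecting a Small Step

The source may report more compounds than this note shows. Statements on the series, on what has been measured and on what is new or still open speak of the compounds shown alone.

In a functional assay on MDA-MB-231 cells (Homo sapiens) for cytotoxicity, read by MTT assay, with a stated time of 96 h (on this read-out higher numbers stand for weaker inhibition and lower numbers for stronger inhibition), compound 2 (`N=C(N)c1ccc(-c2ccc(-c3ccc([N+](=O)[O-])cc3)o2)cc1`) gives 3100 nM as its measured value. Compound 3 (`N=C(N)c1ccc(-c2ccc(-c3cccc([N+](=O)[O-])c3)o2)cc1`), which also carries a nitro group, gives 2900 nM on the same read-out. Compound 1 (`Cn1c(-c2ccccc2)ccc1-c1ccc(C(=N)N)cc1`), which carries no nitro group, gives 2600 nM on that read-out too. These three numbers lie within the usual scatter of one another, so compound 2 stands level with both neighbours.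

Compound 4 (`CC(C)(C)c1ccc(-c2ccc(-c3ccc(C(=N)N)cc3)o2)cc1`) differs from compound 2 in one place, with tert-butyl in place of nitro on an aromatic carbon. Going by the values given here, no measured pair shows this change alone, so the data offer no direct guide to its size. Among the compounds with values here, the only hint is that compound 1 has no nitro group and still gives 2600 nM as its value. In this assay a change beyond the scatter is therefore not expected, and no direction is favoured with confidence. The estimated step, a 1.2-fold lower number from compound 2 to compound 4 (0.09 log units; within the scatter), stays within the scatter. Compound 4 is expected at 2500 nM with a range from 900 nM to 7000 nM as its likely span.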

Compound 4, half-maximal inhibitory concentration: 3200 nM
The estimate for compound 4 lay 1.3-fold (0.11 log units) below the measured number, and the stated range covers the measured number.
By their numbers in this assay, from the lowest: compounds 1, 3, 2 and 4 (each within the scatter of the next).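

In this assay, replacing nitro with tert-butyl on an aromatic carbon para to a large group gives a 1.0-fold higher number from compound 2 to compound 4 (0.01 log units; within the scatter), a step within the scatter. Going by these compounds alone, this is the first direct reading of this change, and it shows that the number holds level even though the two groups differ plainly in makeup: nitro brings nitrogen, oxygen and hydrogen-bond acceptors, while tert-butyl is all carbon and has no hydrogen-bond acceptors. No measurement shown here explains why the two groups read alike.

Going by these compounds, whether an amine or a carboxylic acid at this position would also leave the number level remains open. Also open, on these data alone, is whether the same change would stay within the scatter on a different core, such as the core of compound 1.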